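Will methyl on the amine weaken compound 3?

The compounds below may be only part of what the source reports. "The series", "measured", "known", "first", "only" and "open" are said of these compounds alone.

Measured in a functional assay on MCF7 cells (Homo sapiens) for antiproliferative activity (a lower number here means a stronger inhibitor, a higher number a weaker inhibitor), so far
- Compound 1 `CCCN(CCC)CCCOc1ccc2cc(NC(=O)c3ccc(O)c(CC=C(C)C)c3)c(=O)oc2c1C` gives > 50000 nM which is a limit of the assay
- Compound 2 `CC(C)=CCc1cc(C(=O)Nc2cc3ccc(OCCCNC(C)C)c(C)c3oc2=O)ccc1O` gives 740 nM as a full reading
- Compound 3 `CC(C)=CCc1cc(C(=O)Nc2cc3ccc(OCCCNCc4ccccc4)c(C)c3oc2=O)ccc1O` gives 910 nM as a full reading

Among the measured compounds shown here, compound 3 stands within the scatter of its only numerical neighbour (a 1.2-fold higher number from compound 2 to compound 3 (0.09 log units; within the scatter)). Compound 4 `CC(C)=CCc1cc(C(=O)Nc2cc3ccc(OCCCN(C)Cc4ccccc4)c(C)c3oc2=O)ccc1O` has methyl in place of hydrogen on an amine nitrogen. That leaves the nitrogen without a hydrogen, as in compound 1. Two large steps bear on this (an at least 67-fold lower number from compound 1 to compound 2 (1.82 log units; beyond the scatter)) and (an at least 54-fold lower number from compound 1 to compound 3 (1.73 log units; beyond the scatter)). Compound 1 is a single example, and its dipropylamino differs from benzyl(methyl)amino, so a smaller change is expected here. The expected step in this assay is a 3.3-fold higher number from compound 3 to compound 4 (0.52 log units; beyond the scatter) towards a weaker inhibitor. Compound 4 is estimated at 3000 nM (expected range 600 nM to 30000 nM).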

Compound 4, half-maximal inhibitory concentration: 11500 nM
Compound 4: middle estimate off by 3.8-fold (0.58 log units), on the low side; low and high end bracket the measured number.
By their numbers in this assay, from the lowest: compounds 2 and 3 (each within the scatter of the next); then compound 4. At a limit, above all of these: compound 1.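

In this assay, one added methyl on the amine nitrogen is enough for a large loss on its own: a 13-fold higher number from compound 3 to compound 4 (1.10 log units; beyond the scatter). The isopropylamino compound shows a large gap too, a 16-fold higher number from compound 2 to compound 4 (1.19 log units; beyond the scatter), so among these compounds, those that keep the hydrogen on this nitrogen give the lower numbers. Compound 4 still does not reach the dipropylamino compound, an at least 4.3-fold lower number from compound 1 to compound 4 (0.63 log units; beyond the scatter), a step that starts from a limit of the assay: the limit of > 50000 nM in this assay, at which 1 of the 4 values shown sits.

As far as these compounds go, whether the methyl costs as much on the isopropylamino compound remains open. So does the effect of an ethyl on this nitrogen, or of a piperidine ring containing it.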